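The source may report more compounds than this note shows. Statements on the series, on what has been measured and on what is new or still open speak of the compounds shown alone.

Measured compounds:
- compound 1, `Nc1scc(CN2CCN(c3cc(Cl)cc(Cl)c3)CC2)c1C(=O)c1ccc(Cl)cc1`: 1%
- compound 2, `COc1ccc(N2CCN(Cc3csc(N)c3C(=O)c3ccc(Cl)cc3)CC2)cc1`: 0%
- compound 3, `Nc1scc(CN2CCN(c3cccnc3)CC2)c1C(=O)c1ccc(Cl)cc1`: 0%

All three share one core and differ only in the aromatic group attached to the amine nitrogen of the six-membered ring with two nitrogens. In an assay on CHO cells for displacement of a labelled ligand from adenosine receptor A3 (Homo sapiens), read by scintillation counting, with a stated time of 120 min, tested at 10 uM (on this read-out lower numbers stand for less inhibition and higher numbers for more inhibition at the one concentration tested (going by the name of the read-out)), compound 3 gives 0%, level with compound 2 at the digits shown and together with it the lowest of the three numbers; compound 1 sits one point higher, which is within the scatter. Every step among the measured compounds is small: a number 1 percentage points lower from compound 1 to compound 2 (within the scatter), a number 1 percentage points lower from compound 1 to compound 3 (within the scatter) and no change at the digits printed from compound 2 to compound 3 (within the scatter). None of these changes of the aromatic group moved the read-out beyond the scatter.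

Compound 4, `Nc1scc(CN2CCN(c3cccc(F)c3F)CC2)c1C(=O)c1ccc(Cl)cc1`, has not yet been measured. It differs from compound 3 in one place: 2,3-difluorophenyl in place of pyridin-3-yl on an amine nitrogen in a ring. This is again an exchange of the aromatic group on that ring nitrogen, the same kind of change as the three steps above, each of which stayed within the scatter. The step to compound 4 is therefore expected to be of the same kind, a number 1 percentage points higher from compound 3 to compound 4 (within the scatter), with no change beyond the scatter expected. For compound 4 the estimate in this assay is 1%, expected to lie between -8% and 10%.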

Compound 4, a percentage reported as inhibition, at one concentration (the size of the read-out at that concentration, not a potency): 0%
For compound 4 the middle estimate is 1 percentage points above the measured one; low and high end bracket the measured number.
By their numbers in this assay, from the lowest: compounds 2, 3, 4 and 1 (each within the scatter of the next).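

In this assay, replacing pyridin-3-yl with 2,3-difluorophenyl gives no change at the digits printed from compound 3 to compound 4 (within the scatter), so a ring of carbon only, bearing two fluorines and with no hydrogen-bond acceptor, reads the same as the ring that contains a nitrogen and counts one acceptor. The comparisons with the other two aromatic groups agree, with no change at the digits printed from compound 2 to compound 4 (within the scatter) and a number 1 percentage points lower from compound 1 to compound 4 (within the scatter), which means that four different aromatic groups on this ring nitrogen now sit within the scatter of one another and cannot be ranked by this read-out. No supporting information bears on why the read-out stays so flat at this position.

As far as these compounds go, what remains open is whether a group of another type on that ring nitrogen, such as a plain methyl group, a benzyl group or an acetyl group, would move the number beyond the scatter. The shared core also stays fixed throughout, so these compounds say nothing about changes elsewhere, such as an amide in place of its free amine.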